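Removing a Chloro Group: Expected Effect on Growth Inhibition

The compounds below may be only part of what the source reports. "The series", "measured", "known", "first", "only" and "open" are said of these compounds alone.

Compound 1, `CCCCCCn1cnc2c(Nc3ccc(O)cc3)nc(N[C@H]3CC[C@H](N)CC3)nc21`: 7700 nM
Compound 2, `CC(C)CCn1cnc2c(Nc3ccc(Cl)cc3)nc(N[C@H]3CC[C@H](N)CC3)nc21`: 5100 nM

Both compounds share the same core and were tested in a functional assay on BT-474 cells (Homo sapiens) for inhibition, read by fluorescence, with a stated time of 72 h; a higher number here means a weaker inhibitor of growth, a lower number a stronger inhibitor of growth. In this assay compound 1 gives 7700 nM and compound 2 gives 5100 nM. Compound 2 has the lower of the two numbers, but its gap to compound 1 lies within the scatter of repeated measurements, so the two cannot be told apart on these data. Compound 3, `CC(C)CCn1cnc2c(Nc3ccccc3)nc(N[C@H]3CC[C@H](N)CC3)nc21`, differs from compound 2 in a single place: hydrogen in place of chloro on an aromatic carbon. Within the data shown here, no pair of measured compounds differing in only one place is available, so the size of such a step cannot be read from the measured values. The expected step is a 1.6-fold higher number from compound 2 to compound 3 (0.20 log units; within the scatter), a small move toward a higher number that may well stay within the scatter. For compound 3 the estimated value is 8000 nM, with a likely range from 3000 nM to 22000 nM.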

Compound 3, concentration for 50% growth inhibition: 6400 nM
Estimate against measurement, compound 3: 1.3-fold (0.10 log units) above, within the range that was stated.
By their numbers in this assay, from the lowest: compounds 2, 3 and 1 (each within the scatter of the next).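

Taking the chloro group off the 4-chlorophenyl ring, which leaves a plain phenyl, gives in this assay a 1.3-fold higher number from compound 2 to compound 3 (0.10 log units; within the scatter). This is the first pair shown that differs in one place only, and it indicates that at this position, para to a large group, exchanging chloro for hydrogen produces no change that this measurement can distinguish. Nothing measured here bears on the reason for so small a step.

Compound 1 carries a hydroxyl group at this position but also has a different chain, so it does not show the effect of the hydroxyl group alone. Going by these compounds, it remains open whether another group at this position, such as an amine, a carboxylic acid or a methoxy group, would move the number beyond the scatter.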